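Fluorine on the Aryl Ring of an Arylpiperazine Amide

The compounds below may be only part of what the source reports. "The series", "measured", "known", "first", "only" and "open" are said of these compounds alone.

Measured so far:
compound 1 `CC(C)(C)C(=O)NCCCCN1CCN(c2ccccc2Cl)CC1` — 79.4 nM
compound 2 `CC(C)(C)C(=O)NCCCCN1CCN(c2ccccc2)CC1` — 316 nM

Among the compounds with values here, in an assay on HEK293 cells for binding affinity to D(4) dopamine receptor (Homo sapiens), read by radioligand binding (a higher number here means a weaker inhibitor, a lower number a stronger inhibitor), compound 2 gives 316 nM, the higher of the two numbers known; its only neighbour is compound 1, and that step, a 4.0-fold higher number from compound 1 to compound 2 (0.60 log units; beyond the scatter), came with hydrogen in place of chloro on an aromatic carbon. Compound 3 `CC(C)(C)C(=O)NCCCCN1CCN(c2ccc(F)cc2)CC1` is reached from compound 2 by fluoro in place of hydrogen on an aromatic carbon. Within the data shown here, the one measured step bears only loosely on this change: it removed a chloro group, whereas here a fluoro group enters, and no measured pair shows a fluoro group in this place. The step from compound 2 to compound 3 is therefore expected to be small, a 1.3-fold lower number from compound 2 to compound 3 (0.10 log units; within the scatter), and may not exceed the scatter. For compound 3 in this assay the estimate is 250 nM, expected to fall between 100 nM and 630 nM.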

Compound 3, inhibition constant: 126 nM
Estimate against measurement, compound 3: 2.0-fold (0.30 log units) above; low and high end bracket the measured number.
By their numbers in this assay, from the lowest: compounds 1 and 3 (each within the scatter of the next); then compound 2.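

In this assay the phenyl to 4-fluorophenyl change, a single fluoro group on an aromatic carbon para to a large group, gives a 2.5-fold lower number from compound 2 to compound 3 (0.40 log units; beyond the scatter) and so registers beyond the scatter. Within the data shown here, this is the first sign that a substituent at this place, and not only the chloro group of compound 1, moves the number from that of the unsubstituted compound 2. With a 1.6-fold higher number from compound 1 to compound 3 (0.20 log units; within the scatter) inside the scatter, the 4-fluorophenyl and 2-chlorophenyl groups cannot be told apart in this assay.

Still open, going by these compounds, is whether the gain belongs to fluoro itself or would also come with a methoxy group, an amine or a chloro group on that same para carbon. Nothing available accounts for the size of either step.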